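Bromo in Place of Chloro: an Expected Anticonvulsant Dose

The source may hold more compounds than are shown below. What is called first, only, known or untested is meant among the compounds shown, and "the series" means these compounds.

Three measured compounds share one core and differ at a single aromatic carbon or at the sulfonamide nitrogen. In a functional assay on the whole organism (strain STD-dd) with Mus musculus as the target, in the maximal electroshock model, with a stated time of 2 h (on this read-out higher numbers stand for an effect only at larger amounts of compound and lower numbers for an effect already at smaller amounts), compound 1 `NS(=O)(=O)Cc1noc2ccc(F)cc12` gives 15 mg/kg. Compound 2 `NS(=O)(=O)Cc1noc2ccc(Cl)cc12` gives 14 mg/kg in this assay, and compound 3 `CNS(=O)(=O)Cc1noc2ccc(Cl)cc12` gives 20 mg/kg there. Compound 2 thus holds the lowest of the three numbers, but both other compounds lie within the scatter of it: a 1.1-fold lower number from compound 1 to compound 2 (0.03 log units; within the scatter) and a 1.4-fold higher number from compound 2 to compound 3 (0.15 log units; within the scatter). Compound 4 `NS(=O)(=O)Cc1noc2ccc(Br)cc12` has not yet been measured; it differs from compound 2 by bromo in place of chloro on an aromatic carbon. Within the data shown here, the one measured step that bears on this change is the earlier halogen exchange at the same aromatic carbon, a 1.1-fold lower number from compound 1 to compound 2 (0.03 log units; within the scatter), which produced no shift beyond the scatter. On that basis, no step beyond the scatter is expected in this assay for compound 4 in either direction, and the estimated step is no change at the digits printed from compound 2 to compound 4 (within the scatter). Compound 4 is therefore expected to give 14 mg/kg in this assay, with a range from 7 mg/kg to 28 mg/kg.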

Compound 4, dose for half-maximal effect: 14 mg/kg
Beside the measured number, compound 4's estimate shows no gap at the digits printed; measured number inside the range.
By their numbers in this assay, from the lowest: compounds 2, 4, 1 and 3 (each within the scatter of the next).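

With compound 4, the aromatic carbon now carries a third halogen in this assay, and bromo in place of chloro leaves the dose within the scatter (no change at the digits printed from compound 2 to compound 4 (within the scatter)). Among these compounds, the wider exchange of bromo in place of fluoro also stays within the scatter (a 1.1-fold lower number from compound 1 to compound 4 (0.03 log units; within the scatter)), so fluoro, chloro and bromo cannot be told apart at this position in the three compounds that carry them, whereas the earlier compounds offered only the comparison of fluoro with chloro. Nothing given here explains this lack of separation.

The compounds shown leave open whether this tolerance extends beyond halogens, for instance to an amine, a methoxy group or a carboxylic acid on the same carbon, or whether the dose holds with plain hydrogen there. They also leave open whether methyl in place of hydrogen on the sulfonamide nitrogen would behave alongside bromo as it does alongside chloro.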